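The compounds below may be only part of what the source reports. "The series", "measured", "known", "first", "only" and "open" are said of these compounds alone.

Compound 1 `COc1ccc(-n2c(S)nnc2-c2cc(OC)c(OC)c(OC)c2)cc1` gives, in a functional assay on HCT-116 cells (Homo sapiens) for inhibition, read by MTT assay, with a stated time of 48 h (a lower number here means a stronger inhibitor, a higher number a weaker inhibitor), the value > 60000 nM, which is a limit of the assay and not a number. Compound 2 `COc1ccc(-n2c(SCc3ccccc3)nnc2-c2cc(OC)c(OC)c(OC)c2)cc1` gives 42400 nM. Compound 3 `COc1cc(-c2nnc(SCc3ccccc3)n2-c2ccc(N(C)C)cc2)cc(OC)c1OC` gives 54000 nM.

Among the two numbers, compound 3 gives the higher one, and its gap to compound 2 is within the scatter. Compound 4 `COc1ccc(NC(=O)CSc2nnc(-c3cc(OC)c(OC)c(OC)c3)n2-c2ccc(N(C)C)cc2)cc1` differs from compound 3 at one place: (4-methoxyphenyl)carbamoyl in place of phenyl on a saturated chain carbon bound to a sulfur. Going by the values given here, two measured steps touch the same region. The first, an at least 1.4-fold lower number from compound 1 to compound 2 (0.15 log units; that floor lies within the scatter), has a floor within the scatter. The second, a 1.3-fold higher number from compound 2 to compound 3 (0.11 log units; within the scatter), sits within the scatter too. Neither involves the group that enters here, so both are weak guides; they suggest small movements. For compound 4 the expected step is a 1.2-fold lower number from compound 3 to compound 4 (0.08 log units; within the scatter), nothing beyond the scatter. Compound 4 is estimated at 45000 nM, ranging from 15000 nM to 90000 nM.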

Compound 4, half-maximal inhibitory concentration: > 60000 nM
Compound 4 was reported as a limit (the forecaster's own chance of this, stated with the estimate: 35%); at least 1.3-fold (0.12 log units) between middle value and limit.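

The step gives an at least 1.1-fold higher number from compound 3 to compound 4 (0.04 log units; that floor lies within the scatter), so placing (4-methoxyphenyl)carbamoyl on a saturated chain carbon bound to a sulfur brought no sign of stronger inhibition. On these data alone, compound 4 gives > 60000 nM, which is a limit and not a number, so the real size of this step stays unknown. This is the first change at this position that leaves the benzyl group behind, and its result ends at the same ceiling as compound 1: the limit of > 60000 nM in this assay, at which 2 of the 4 values shown sit.

As far as these compounds go, whether a carboxylic acid or a simple amine on that chain carbon would lower the number remains open. So does whether the methoxy group on the new ring matters at all.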